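Cytotoxicity of the cyclopropyl imidazolone series: ethyl to trifluoromethyl

A few compounds are considered here, and "the series" means these few. Any claim that something is new, unique, unknown or untested is made for them only; others in the source may bear on it.

Measured compounds in an ADME assay on HEp-2 cells (Homo sapiens) for cytotoxicity, read by CCK-8 assay, with a stated time of 6 days; on this read-out lower numbers stand for higher toxicity in this test and higher numbers for lower toxicity in this test:
compound 1, `O=c1n(Cc2nc3ccc(F)cn3c2CCCCO)c2cnccc2n1C1CC1`, gives > 100000 nM.
compound 2, `O=c1n(Cc2nc3ccc(C(F)(F)F)cn3c2CCCCO)c2cnccc2n1C1CC1`, gives > 100000 nM.
compound 3, `CCc1ccn2c(CCCCO)c(Cn3c(=O)n(C4CC4)c4ccncc43)nc2c1`, gives > 100000 nM.

Each of these values is a limit of this assay and not a number. Compound 3 therefore stands at the limit, and the two other values shown stand at the same limit, so no ordering among the three is readable. Among the compounds with values here, the one step between measured compounds that differ in one place, a step that the two limits leave unreadable from compound 1 to compound 2, is left unreadable by the two limits on either side of it.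

Compound 4, `O=c1n(Cc2nc3cc(C(F)(F)F)ccn3c2CCCCO)c2cnccc2n1C1CC1`, has not been measured in this assay. It differs from compound 3 by trifluoromethyl in place of ethyl on an aromatic carbon. Within the data shown here, no measured step reports the effect of this exchange, and the only evidence bearing on it is the limit of > 100000 nM in this assay, at which 3 of the 3 values shown sit, at which all three measured values sit. On that basis the step of a number no higher from compound 3 to compound 4 (the limit leaves the size open) from compound 3 to compound 4 is expected to be none beyond the scatter, and compound 4 is estimated at 100000 nM, with a range from 40000 nM to 300000 nM, most probably reported again as a limit.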

Compound 4, half-maximal cytotoxic concentration: > 100000 nM
Compound 4 ended at the assay's limit; the forecaster's own chance of this, stated with the estimate: 85%; the middle value lies on the limit itself.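

No new step can be read between compound 3 and compound 4, as both values in this assay are limits and not numbers: the limit of > 100000 nM in this assay, at which 4 of the 4 values shown sit.

The compounds shown leave open whether exchanging fluoro, ethyl and trifluoromethyl changes the read-out in this assay at all, and at what concentration any of the compounds would reach the half-maximal cytotoxic effect.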